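A few compounds are considered here, and "the series" means these few. Any claim that something is new, unique, unknown or untested is made for them only; others in the source may bear on it.

Compound 1 `COc1cccc(N2C(=O)COc3ccc(-c4cnc(Cl)c(NS(=O)(=O)c5ccc(F)cc5)c4)cc32)c1`: 32700 nM
Compound 2 `COc1cccc(N2C(=O)COc3ccc(-c4cnc(OC)c(NS(=O)(=O)c5ccc(F)cc5)c4)cc32)c1`: 11200 nM

Among the measured compounds shown here, in a functional assay on A549 cells (Homo sapiens) for antiproliferative activity, read by MTT assay, with a stated time of 72 h (a higher number here means a weaker inhibitor, a lower number a stronger inhibitor), compound 1 gives 32700 nM, the higher of the two numbers measured so far, so the series starts from weak antiproliferative activity. The next structure is compound 3 `O=C1COc2ccc(-c3cnc(Cl)c(NS(=O)(=O)c4ccc(F)cc4)c3)cc2N1c1ccc(F)cc1`, which keeps the chloro group of compound 1 and changes the other aryl substituent. The difference is 4-fluorophenyl in place of 3-methoxyphenyl on an amide-type nitrogen in a ring. In words, this is 4-fluorophenyl in place of 3-methoxyphenyl on an amide-type nitrogen in a ring.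

For the measured compounds named here, no measured step covers a change at this place. Going by the values given here, the only step available is methoxy in place of chloro on an aromatic carbon, a 2.9-fold lower number from compound 1 to compound 2 (0.47 log units; beyond the scatter), which is modest and concerns a different substituent. It gives a rough idea of size and no direction for the present change. With no evidence for a direction, no shift beyond the scatter is expected in this assay, and the expected step is a 1.1-fold lower number from compound 1 to compound 3 (0.04 log units; within the scatter). The estimate for compound 3 is 30000 nM, with an expected range of 12000 nM to 70000 nM.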

Compound 3, half-maximal inhibitory concentration: 22300 nM
Estimate against measurement, compound 3: 1.3-fold (0.13 log units) above, within the range that was stated.
By their numbers in this assay, from the lowest: compounds 2, 3 and 1 (each within the scatter of the next, the first and the last beyond it).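

In this assay, among the compounds shown here, 4-fluorophenyl in place of 3-methoxyphenyl on the amide-type nitrogen in a ring gives a 1.5-fold lower number from compound 1 to compound 3 (0.17 log units; within the scatter), the first reading at this position, and it shows that one aryl group can be exchanged for the other here with no shift that can be told from the scatter. For the compounds shown here, the only other step, a 2.9-fold lower number from compound 1 to compound 2 (0.47 log units; beyond the scatter), concerns a different substituent and is printed as beyond the scatter, so for now the change on the aromatic carbon is the only one of the two with a readable effect, though both are single pairs and neither defines a trend. No measured data bear on why this exchange of aryl groups leaves the number within the scatter.

With only these two aryl groups shown, and only alongside the chloro group, it remains open how the same position responds to something of another kind on that nitrogen, such as an amine-bearing chain, a carboxylic acid or a longer alkyl chain. On these data alone, it also remains open whether 4-fluorophenyl at this position gives a similar reading when methoxy replaces chloro on the aromatic carbon.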